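Tetrazole Amide Tail Tested at One Concentration

The compounds below may be only part of what the source reports. "The series", "measured", "known", "first", "only" and "open" are said of these compounds alone.

Compound 2 `CCc1cc(C(C)=O)c(O)cc1OCCCCCCC(=O)N(C)C` gives 100% in an assay on isolated protein for inhibition of leukotriene B4 receptor 1 (Homo sapiens), tested at 10 uM; on this read-out lower numbers stand for less inhibition and higher numbers for more inhibition at the one concentration tested (going by the name of the read-out). Among the compounds with values here, compound 1 `CCc1cc(C(C)=O)c(O)cc1OCCCCCC(C)(C)C(=O)O` gives 104% in this assay, so compound 2 sits within the scatter of the only other measured compound, and both numbers are level with each other.

Compound 3 `CCc1cc(C(C)=O)c(O)cc1OCCCCCCC(=O)Nc1nn[nH]n1` carries one change on the tail: (2H-tetrazol-5-yl)amino in place of dimethylamino on a carbonyl carbon. Within the data shown here, no measured step touches this exact change. Among the measured compounds shown here, the one step available, a number 4 percentage points lower from compound 1 to compound 2 (within the scatter), replaced the tail end without moving the read-out beyond the scatter. By that precedent, the expected step for compound 3 is a number 2 percentage points lower from compound 2 to compound 3 (within the scatter). Compound 3 is therefore estimated at 98%, within 80% to 105%.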

Compound 3, a percentage reported as inhibition, at one concentration (the size of the read-out at that concentration, not a potency): 101%
Compound 3: the middle estimate sits 3 percentage points below what was measured; the range from low to high includes it.
By their numbers in this assay, from the lowest: compounds 2, 3 and 1 (each within the scatter of the next).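

In this assay, the larger (2H-tetrazol-5-yl)amino group on the carbonyl carbon gives a number 1 percentage points higher from compound 2 to compound 3 (within the scatter), so adding a ring and hydrogen-bond donors at this position leaves the number level. The comparison with the acid-bearing tail gives a number 3 percentage points lower from compound 1 to compound 3 (within the scatter), so three different tail ends now read alike at this one concentration. No measurement here explains this result. Still open, going by these compounds, is whether an amine at the tail end or a shorter chain would also read level. On these data alone, a single concentration also gives no potency, so any potency differences among the three remain unknown.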